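Trading a Hydroxy for Hydrogen on a Side Chain

The compounds below may be only part of what the source reports. "The series", "measured", "known", "first", "only" and "open" are said of these compounds alone.

Measured so far:
- compound 1, `C=CCc1cc(O)c(O)c(CN2CCC(CO)CC2)c1`: 49.4%
- compound 2, `C=CCc1ccc(OCc2cn(-c3ccccc3Cl)nn2)c(O)c1`: 42.8%
- compound 3, `C=CCc1ccc(OCc2cn(-c3cc(OC)c(OC)c(OC)c3)nn2)c(O)c1`: 55.9%

Of the compounds shown here, three have been tested in a functional assay on SK-N-SH cells (Homo sapiens) for inhibition, read by MTT assay, with a stated time of 72 h, tested at 50 uM; a lower number here means less inhibition of growth, a higher number more inhibition of growth at the concentration tested. Compound 1 gives 49.4%, compound 2 gives 42.8%, and compound 3 gives 55.9%. Compound 1 stands between the other two numbers, but its gap to compound 3 and its gap to compound 2 each fall within the usual scatter of repeated measurements, so the three cannot be told apart on these numbers alone. Nothing can be said about which of them inhibits growth more.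

Compound 4, `C=CCc1cc(O)c(O)c(CN2CCC(C)CC2)c1`, has not yet been measured. It differs from compound 1 in one place: hydrogen in place of hydroxy on a saturated chain carbon bound to a saturated ring carbon. Cut one bond further out, the same change reads hydroxymethyl to methyl. For the measured compounds named here, no pair of measured compounds shares this kind of change, so there is no measured step to lean on. In this assay a step within the scatter is expected, with no clear direction; the hydroxy group leaves only a small part of the shared core untouched by anything else.

For compound 4 the expected value in this assay is 48%, with a likely range from 35% to 62%, which would mean a step of a number 1.4 percentage points lower from compound 1 to compound 4 (within the scatter).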

Compound 4, percent growth inhibition at one concentration: 84.2%
Beside the measured number, compound 4's estimate is 36.2 percentage points below it; the measured number lies above the stated range.
By their numbers in this assay, from the lowest: compounds 2, 1 and 3 (each within the scatter of the next, the first and the last beyond it); then compound 4.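

For the compounds shown here, until now no two compounds differed in one place, so nothing could be said about any single position on its own; compound 1 and compound 4 supply the first such comparison. In this assay, hydrogen in place of hydroxy on a saturated chain carbon bound to a saturated ring carbon gives a number 34.8 percentage points higher from compound 1 to compound 4 (beyond the scatter) and so marks this end of the side chain as a place where the read-out responds strongly. The change is small on paper, since hydroxymethyl becomes methyl and only 1 heavy atom (1 oxygen) leaves, so even a single atom at this position can separate two compounds well beyond the usual scatter at the one concentration tested.

This single pair does not show how the read-out would respond to other groups at the same place, such as an aminomethyl group, a carboxylic acid, a methoxymethyl group or a longer chain like ethyl or propyl. Why hydrogen goes with more inhibition of growth than hydroxy here also stays open, as no measurement at hand bears on the reason for this step.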